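Swapping an acyl group for a sulfonyl group

The source may hold more compounds than are shown below. What is called first, only, known or untested is meant among the compounds shown, and "the series" means these compounds.

Measured compounds:
- Compound 1, `COC(=O)CC(=O)N1N=C(c2ccc(N3CCN(C)CC3)cc2)CC1c1ccc(N(C)C)cc1`, in a functional assay on NCI-H1975 cells (Homo sapiens) for inhibition, read by sulforhodamine B assay, tested at 10 uM; on this read-out higher numbers stand for more inhibition at the one concentration tested (going by the name of the read-out) and lower numbers for less inhibition: -2.2%
- Compound 2, `CN1CCN(c2ccc(C3=NN(S(=O)(=O)c4ccc(C#N)cc4)C(c4ccc(N(C)C)cc4)C3)cc2)CC1`, in this assay: 100%
- Compound 3, `COC(=O)CC(=O)N1N=C(c2ccc(-n3cncn3)cc2)CC1c1ccc(N(C)C)cc1`, in this assay: 1.5%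

Compound 3 stands second among the three numbers. The step of a number 3.7 percentage points higher from compound 1 to compound 3 (within the scatter) lies within the scatter, so compounds 1 and 3 cannot be told apart on these data, while compound 2 lies far above both of them.

Compound 4, `CN(C)c1ccc(C2CC(c3ccc(-n4cncn4)cc3)=NN2S(=O)(=O)c2ccc(F)cc2)cc1`, has not yet been measured. It differs from compound 3 in one place: (4-fluorophenyl)sulfonyl in place of ((methoxycarbonyl)methyl)carbonyl on an amine nitrogen in a ring. Going by the values given here, one measured step bears on this change: a number 102.2 percentage points higher from compound 1 to compound 2 (beyond the scatter), where the same ((methoxycarbonyl)methyl)carbonyl group left the same ring nitrogen and a (4-cyanophenyl)sulfonyl group entered. Compound 4 receives a (4-fluorophenyl)sulfonyl group instead, and nothing measured here separates the two sulfonyl groups from each other. Taking the one measured step as the guide, a large rise is expected: a number 83.5 percentage points higher from compound 3 to compound 4 (beyond the scatter). Compound 4 is therefore estimated at 85%, with a range from 50% to 100%, the lower end allowing for the fluorine in place of the nitrile.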

Compound 4, a percentage reported as inhibition, at one concentration (the size of the read-out at that concentration, not a potency): -0.5%
Beside the measured number, compound 4's estimate is 85.5 percentage points above it; measured number outside the range, below it.
By their numbers in this assay, from the lowest: compounds 1, 4 and 3 (each within the scatter of the next); then compound 2.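

In this assay, the swap on the amine nitrogen in a ring gives a number 2 percentage points lower from compound 3 to compound 4 (within the scatter), while the earlier swap at the same nitrogen gave a number 102.2 percentage points higher from compound 1 to compound 2 (beyond the scatter). An arylsulfonyl group at this position is therefore not enough on its own to raise the number: where the aromatic carbon carries 1H-1,2,4-triazol-1-yl, replacing ((methoxycarbonyl)methyl)carbonyl with (4-fluorophenyl)sulfonyl leaves the reading within the scatter of compound 3. Nothing available explains why the two steps differ so widely.

Compound 2 and compound 4 differ in two places, the group on the sulfonyl-bound phenyl ring and the group on the aromatic carbon, so the compounds shown cannot tell whether the high number of compound 2 goes with the nitrile, with 4-methylpiperazin-1-yl, or only with the two together. Also open, as far as these compounds go, is how a plain phenylsulfonyl group on the ring nitrogen, or a morpholin-4-yl group on the aromatic carbon, would read.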